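From pyridin-3-yl to pyridin-4-yl on the amine chain

The compounds below may be only part of what the source reports. "The series", "measured", "known", "first", "only" and "open" are said of these compounds alone.

In a physicochemical assay for lipophilicity, read by HPLC (a lower number here means a more polar compound, a higher number a more lipophilic compound), compound 1 (`COc1ccc(NC[C@H](O)COc2ccc(N3C[C@H](CNC(C)=O)OC3=O)cc2F)cc1`) gives 0.95 while compound 2 (`CC(=O)NC[C@H]1CN(c2ccc(OC[C@@H](O)CNc3cccnc3)c(F)c2)C(=O)O1`) gives 0.02 and compound 3 (`CC(=O)NC[C@H]1CN(c2ccc(OC[C@H](O)CNc3cccnc3)c(F)c2)C(=O)O1`) gives -0.18 on the same scale. Compound 3 therefore stands with compound 2, within the scatter, and compound 1 lies clear of both, beyond the scatter.

Compound 4 (`CC(=O)NC[C@H]1CN(c2ccc(OC[C@@H](O)CNc3ccncc3)c(F)c2)C(=O)O1`) comes from compound 3 through a single change: 1-hydroxy-2-((pyridin-4-yl)amino)ethyl in place of 1-hydroxy-2-((pyridin-3-yl)amino)ethyl on a saturated chain carbon bound to an oxygen on an aromatic ring with the same atoms joined differently.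

Going by the values given here, two measured steps bear on this change. Pyridin-3-yl in place of 4-methoxyphenyl on an amine nitrogen gave a number 0.93 log units lower from compound 1 to compound 2 (beyond the scatter) and is the only measured swap of the aromatic group on that nitrogen, although it exchanges atoms and the present change does not. The other step, a number 0.20 log units lower from compound 2 to compound 3 (within the scatter), rests on the fact that compounds 2 and 3 differ only in the configuration as drawn and gives no reason to expect anything from configuration. Among the compounds with values here, a step well short of the first is expected, possibly not beyond the scatter, with a slight lean towards lower numbers, the direction of the one measured swap. The expected size is a number 0.27 log units lower from compound 3 to compound 4 (within the scatter) in this assay terms. For compound 4 the estimated value is -0.45 with an expected range from -1 to 0.05 in this read-out.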

Compound 4, partition coefficient: -0.04
Beside the measured number, compound 4's estimate is 0.41 log units below it; the range from low to high includes it.
By their numbers in this assay, from the lowest: compounds 3, 4 and 2 (each within the scatter of the next); then compound 1.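

In this assay, pyridin-4-yl in place of pyridin-3-yl on the amine nitrogen gives a number 0.06 log units lower from compound 2 to compound 4 (within the scatter), with compound 4 drawn in the chain configuration of compound 2, and the comparison with the other configuration gives a number 0.14 log units higher from compound 3 to compound 4 (within the scatter), so neither step separates the two pyridines at this position. The distance from the 4-methoxyphenyl compound persists with the new pyridine, at a number 0.99 log units lower from compound 1 to compound 4 (beyond the scatter) alongside the earlier a number 0.93 log units lower from compound 1 to compound 2 (beyond the scatter), so among compounds 1, 2 and 4 the separation goes with leaving 4-methoxyphenyl, and the choice between pyridin-3-yl and pyridin-4-yl does not register in this assay. Configuration on the chain can be read from one pair only, because only there is it the sole difference: the fact that compounds 2 and 3 differ only in the configuration as drawn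

Still open, going by these compounds, is whether the insensitivity holds beyond these two pyridines, for example with pyridin-2-yl, a pyrimidine ring or an unsubstituted phenyl on the same amine nitrogen. Also open, on these data alone, is what a methyl group on that nitrogen, or a longer chain between the hydroxyl carbon and the amine, would do to the reading in this assay.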